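Compound 4: Ethylcarbamoyl Pyrrolidinyl in Place of Oxopyrrolidinyl

This account rests on a few compounds, and the source may have more. Where it says the series, first, only, none or still open, it means among the compounds named here.

Three measured compounds share one core and differ only in the group on the carbonyl carbon attached to the amide-type nitrogen in a ring. Compound 1 `CN(C)CC(=O)N1CCC(NS(=O)(=O)c2cc(S(=O)(=O)c3ccccc3)ccc2C(F)(F)F)CC1` carries a (dimethylamino)methyl there, and in an assay on isolated protein for binding affinity to secreted frizzled-related protein 1 (Homo sapiens), read by fluorescence (a higher number here means a weaker inhibitor, a lower number a stronger inhibitor), compound 1 gives 300 nM. Compound 2 `CC(C)(C)OC(=O)N1C(=O)CC[C@H]1C(=O)N1CCC(NS(=O)(=O)c2cc(S(=O)(=O)c3ccccc3)ccc2C(F)(F)F)CC1` gives 130 nM, and compound 3 `O=C1CC[C@@H](C(=O)N2CCC(NS(=O)(=O)c3cc(S(=O)(=O)c4ccccc4)ccc3C(F)(F)F)CC2)N1` gives 90 nM. Compound 3 thus holds the lowest of the three numbers: the step of a 3.3-fold lower number from compound 1 to compound 3 (0.52 log units; beyond the scatter) lies beyond the scatter, whereas a 1.4-fold lower number from compound 2 to compound 3 (0.16 log units; within the scatter) does not, so compounds 2 and 3 cannot be told apart.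

Compound 4 `CCNC(=O)N1CCC[C@H]1C(=O)N1CCC(NS(=O)(=O)c2cc(S(=O)(=O)c3ccccc3)ccc2C(F)(F)F)CC1` has not yet been measured. 1-(ethylcarbamoyl)pyrrolidin-2-yl in place of 5-oxopyrrolidin-2-yl on a carbonyl carbon Neither measured step covers this change directly. The closest comparison is compound 2, where a tert-butoxycarbonyl on the amide-type nitrogen in the ring left the number close to that of compound 3, as a 1.4-fold lower number from compound 2 to compound 3 (0.16 log units; within the scatter) shows. For the measured compounds named here, the replacement of the 5-oxopyrrolidin-2-yl itself, however, has no precedent among the measured compounds. The chemist therefore expects only a small step, a 1.7-fold higher number from compound 3 to compound 4 (0.22 log units; within the scatter), not clearly beyond the scatter. For compound 4 the estimate is 150 nM, with a range from 60 nM to 400 nM.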

Compound 4, half-maximal inhibitory concentration: 30 nM
Beside the measured number, compound 4's estimate is 5.0-fold (0.70 log units) above it, and the stated range ends above it.
By their numbers in this assay, from the lowest: compound 4; then compounds 3 and 2 (each within the scatter of the next); then compound 1.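

For the compounds shown here, at the carbonyl carbon whose other neighbour is the amide-type nitrogen in a ring, this assay records a 3.0-fold lower number from compound 3 to compound 4 (0.48 log units; beyond the scatter) when 1-(ethylcarbamoyl)pyrrolidin-2-yl replaces 5-oxopyrrolidin-2-yl, the first step beyond the scatter among the compounds that carry a five-membered ring at this position. The earlier change on the ring nitrogen, from tert-butoxycarbonyl to hydrogen, had stayed within the scatter, so this position now shows that a larger group of 10 heavy atoms, with no oxo group on its ring, can give a lower number than the 6-atom group it replaces. With a 10-fold lower number from compound 1 to compound 4 (1.00 log units; beyond the scatter) in this assay as well, the span seen at this one position grows, while no evidence accounts for the result.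

The step from compound 3 to compound 4 removes the 5-oxo group and adds the ethylcarbamoyl together, so the compounds shown leave open which of the two carries the change. A plain pyrrolidin-2-yl with hydrogen on its ring nitrogen, a methylcarbamoyl or a propylcarbamoyl on that nitrogen, and the opposite configuration at the defined stereocentre would each bear on this question, and none of them is among the compounds shown.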